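Swapping the Amide Aryl Group: Expected Change in Edema Inhibition

A few compounds are considered here, and "the series" means these few. Any claim that something is new, unique, unknown or untested is made for them only; others in the source may bear on it.

Measured compounds in a functional assay on the whole organism (strain C57BL/6) for inhibition, with Mus musculus as the target, read by paw edema, with stated times of 1 h and 4 h, at a dose of 100 mg/kg by the oral route; on this read-out lower numbers stand for less inhibition and higher numbers for more inhibition at the one dose given (going by the name of the read-out):
compound 1 `CC(=O)Nc1ccc(Cc2noc(CCC(=O)Nc3ccc(F)cc3)n2)cc1` gives 64.4%
compound 2 `COc1ccc(NC(=O)CCc2nc(Cc3ccc(NC(C)=O)cc3)no2)cc1F` gives 60.3%
compound 3 `CC(=O)Nc1ccc(Cc2noc(CCC(=O)Nc3cccc(C)c3)n2)cc1` gives 16.4%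

Compound 3 stands lowest of the three measured compounds in this assay. The step of a number 43.9 percentage points lower from compound 2 to compound 3 (beyond the scatter) and the step of a number 48 percentage points lower from compound 1 to compound 3 (beyond the scatter) are both well beyond the usual scatter, so compound 3 clearly gives the lowest number of the three. Compound 1 and compound 2 differ from each other by a number 4.1 percentage points lower from compound 1 to compound 2 (within the scatter), which is within the scatter.

Compound 4 `CC(=O)Nc1ccc(Cc2noc(CCC(=O)Nc3ccc(C(F)(F)F)cc3)n2)cc1` arises from compound 3 by the following change: 4-(trifluoromethyl)phenyl in place of 3-methylphenyl on an amide-type nitrogen.

Among the compounds with values here, two measured steps bear on this. Both compound 1 and compound 2 carry a phenyl ring with fluorine on the amide-type nitrogen, and replacing those rings with 3-methylphenyl cost a large amount in each case. Compound 4 moves back toward a fluorine-bearing phenyl ring, here 4-(trifluoromethyl)phenyl, a ring not yet tested, so the exact size is uncertain. A large rise in this assay is therefore expected, in the direction of compound 1 and compound 2.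

Compound 4 is estimated to give 52%, with an expected range from 25% to 75%, meaning an expected step of a number 35.6 percentage points higher from compound 3 to compound 4 (beyond the scatter).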

Compound 4, a percentage reported as inhibition, in the whole organism at one dose (the size of the read-out at that dose, not a potency): 37%
The estimate for compound 4 lay 15 percentage points above the measured number; the measured number falls inside the stated range.
By their numbers in this assay, from the lowest: compound 3; then compound 4; then compounds 2 and 1 (each within the scatter of the next).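

Putting 4-(trifluoromethyl)phenyl in place of 3-methylphenyl on the amide-type nitrogen gives a number 20.6 percentage points higher from compound 3 to compound 4 (beyond the scatter) in this assay, so the low number of compound 3 is not the floor for this position. The recovery is only partial: trifluoromethyl in place of fluoro on the aromatic carbon gives a number 27.4 percentage points lower from compound 1 to compound 4 (beyond the scatter), and 4-(trifluoromethyl)phenyl in place of 3-fluoro-4-methoxyphenyl gives a number 23.3 percentage points lower from compound 2 to compound 4 (beyond the scatter). This position therefore shows three separate levels rather than two, and compound 4 shows that fluorine on the ring does not by itself restore the level of compound 1 and compound 2, while no measurement offered here explains these differences.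

Compound 3 and compound 4 differ in both the group on the ring and where it sits, so the step cannot be assigned to either change alone; 4-methylphenyl or 3-(trifluoromethyl)phenyl would separate the two. As far as these compounds go, it also remains open how a phenyl ring carrying an amine or a carboxylic acid would fare at this position.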